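This account rests on a few compounds, and the source may have more. Where it says the series, first, only, none or still open, it means among the compounds named here.

Working notes on the series

Of the compounds shown here, two have been measured so far. Compound 1 `CN(CCCn1ccnc1)C(=O)[C@@H]1CCCN1c1nccc(Nc2ccccc2)n1` gives 1% in an assay on isolated protein for inhibition of tyrosine-protein kinase Fes/Fps (Homo sapiens), read by HTRF, tested at 10 uM; on this read-out higher numbers stand for more inhibition at the one concentration tested (going by the name of the read-out) and lower numbers for less inhibition. Compound 2 `COC[C@@H]1CCCN1C(=O)[C@@H]1CCCN1c1nccc(Nc2ccccc2)n1` gives 8% in this assay. Of the two numbers, compound 2 reads as the higher one, but the step of a number 7 percentage points higher from compound 1 to compound 2 (within the scatter) lies within the scatter, so the two compounds cannot be told apart on these data; both sit near the bottom of the read-out.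

Compound 3 `CN(C)CC(C)(C)CNC(=O)[C@@H]1CCCN1c1nccc(Nc2ccccc2)n1` is not yet measured. It differs from compound 2 as follows: (2-((dimethylamino)methyl)-2-methylpropyl)amino in place of 2-(methoxymethyl)pyrrolidin-1-yl on a carbonyl carbon. Among the measured compounds shown here, the only measured step that bears on this change is the one from compound 1 to compound 2, which also exchanged the whole substituent on the same carbonyl carbon and gave a number 7 percentage points higher from compound 1 to compound 2 (within the scatter). That step was within the scatter, and the present change is of the same kind, a further exchange at the same place while the rest of the shared core is kept. No step beyond the scatter is therefore expected in this assay for compound 3.

The expected step is a number 4 percentage points lower from compound 2 to compound 3 (within the scatter). Compound 3 is estimated at 4%, with a range from -8% to 18%.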

Compound 3, a percentage reported as inhibition, at one concentration (the size of the read-out at that concentration, not a potency): 20%
Beside the measured number, compound 3's estimate is 16 percentage points below it, and the stated range ends below it.
By their numbers in this assay, from the lowest: compounds 1 and 2 (each within the scatter of the next); then compound 3.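

In this assay the group on the carbonyl carbon can now be seen to move the read-out beyond the scatter, with a number 12 percentage points higher from compound 2 to compound 3 (beyond the scatter) for (2-((dimethylamino)methyl)-2-methylpropyl)amino in place of 2-(methoxymethyl)pyrrolidin-1-yl and a number 19 percentage points higher from compound 1 to compound 3 (beyond the scatter) for the same group in place of (3-(1H-imidazol-1-yl)propyl)(methyl)amino. Among the compounds shown here, the earlier exchange at this place did not separate its two compounds, so compound 3 is the first to stand apart from the others, though both of its steps are modest. Against the 2-(methoxymethyl)pyrrolidin-1-yl group, the entering group has no ring and carries a hydrogen-bond donor, and nothing available explains the rise.

With the ring, the donor and the dimethylamino end all changing in one exchange, the compounds shown cannot say which of these features goes with the higher number. Open questions are whether a primary amine or a carboxylic acid in place of the dimethylamino end, or a longer chain, would keep, raise or lose the effect in this assay on this shared core.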